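This account rests on a few compounds, and the source may have more. Where it says the series, first, only, none or still open, it means among the compounds named here.

Compounds with a measured value in an assay on isolated protein for inhibition of Gonadotropin-releasing hormone receptor (Rattus norvegicus); a lower number here means a stronger inhibitor, a higher number a weaker inhibitor:

compound 1, `Cc1cccc(CSc2nc3cc(NC(=O)C4CC4)ccc3n2C(C)C)c1`
compound 2, `CC(C)n1c(SCc2ccccc2Cl)nc2cc(NC(=O)C3CC3)ccc21`
compound 3, `COc1ccc([N+](=O)[O-])cc1CSc1nc2cc(NC(=O)NC(C)(C)C)ccc2n1C1CC1`

In this assay compound 1 gives > 10000 nM, which is a limit of the assay rather than a number. Compound 2 likewise gives only a limit, > 10000 nM. Among the compounds with values here, compound 3 gives 860 nM, the only number among the three. The change from compound 1 to compound 2, 2-chlorophenyl in place of 3-methylphenyl on a saturated chain carbon bound to a sulfur, is a step that the two limits leave unreadable from compound 1 to compound 2, because both sit at the limit of > 10000 nM in this assay, at which 2 of the 3 values shown sit. Within the data shown here, compound 3 therefore stands alone as the one compound with a readable value, and no measured pair in this set gives a step whose size can be read.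

Compound 4, `CCCCn1c(SCc2cc([N+](=O)[O-])ccc2OC)nc2cc(NC(=O)NC(C)(C)C)ccc21`, is not yet measured in this assay. It differs from compound 3 by butyl in place of cyclopropyl on an aromatic nitrogen. Among the measured compounds shown here, no measured step touches the group on the aromatic nitrogen; the only compared pair changes a different part of the molecule and is unreadable in any case. With nothing to point in either direction, the expected step from compound 3 to compound 4 is a 1.0-fold higher number from compound 3 to compound 4 (0.02 log units; within the scatter), which stays within the usual scatter. Compound 4 is accordingly estimated at 900 nM, between 300 nM and 3000 nM.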

Compound 4, half-maximal inhibitory concentration: 330 nM
Compound 4: middle estimate off by 2.7-fold (0.44 log units), on the high side, within the range that was stated.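

In this assay, the group on the aromatic nitrogen gives the first step of readable size among these compounds, a 2.6-fold lower number from compound 3 to compound 4 (0.42 log units; beyond the scatter), with butyl in place of cyclopropyl. The step lies beyond the scatter, so within this one pair the open chain gives the stronger inhibitor, and the three-membered ring is not needed at this position for binding to be measured as a number rather than a limit. Nothing measured here says why butyl gives the lower number.

The compounds shown leave open whether a longer chain such as hexyl, or a ring-bearing group such as benzyl, would lower the number further on this nitrogen, as a single pair gives the size of one change and no trend. They also leave open whether the same step would appear with the cyclopropyl amide of compound 1 and compound 2 in place of the tert-butyl urea, as those two compounds differ from compound 3 and compound 4 in more than one place and cannot be compared with them.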